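A few compounds are considered here, and "the series" means these few. Any claim that something is new, unique, unknown or untested is made for them only; others in the source may bear on it.

Measured in an assay on isolated protein for inhibition of protein deacetylase HDAC6 (Homo sapiens), read by fluorescence, tested at 100 uM; a lower number here means less inhibition, a higher number more inhibition at the concentration tested (going by the name of the read-out):
- compound 1 `O=C(NC(=S)NCc1ccc(C(F)(F)F)cc1)c1ccccc1`: "not active" (no number reported)
- compound 2 `O=C(NC(=S)NCc1cccs1)c1ccccc1`: 10%

Among the measured compounds shown here, compound 2 is the only compound with a numerical result in this assay; compound 1 was reported without a number. Compound 2 thus stands alone on the numbers shown, and its inhibition at the tested concentration is low. The next compound, compound 3 `O=C(NC(=S)NCc1ccccc1)c1ccccc1`, differs from compound 2 in one place: phenyl in place of thiophen-2-yl on a saturated chain carbon bound to an amide-type nitrogen. For the measured compounds named here, no step between measured compounds is available to anchor this change, so the expectation rests on compound 2 alone. Given that compound 2 gives 10% in this assay, and compound 1 is reported without activity, compound 3 is expected to stay in the same low region, with the step from compound 2 to compound 3 estimated at a number 2 percentage points lower from compound 2 to compound 3 (within the scatter), not beyond the scatter. Compound 3 is therefore estimated at 8% in this assay, in the range 0% to 20%.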

Compound 3, a percentage reported as inhibition, at one concentration (the size of the read-out at that concentration, not a potency): "not active" (no number reported)
The entry for compound 3 holds no number; the estimate stays without a comparison.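

In this assay, among the compounds shown here, compound 3 is reported as "not active" (no number reported) and so gives no number to set against compound 2, and no step between the two can be read. The compounds shown leave open how phenyl in place of thiophen-2-yl bears on inhibition. Nothing available offers an explanation for this result.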